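The source may report more compounds than this note shows. Statements on the series, on what has been measured and on what is new or still open speak of the compounds shown alone.

Measured so far in a functional assay on ECa-109 cells for inhibition, with ECa-109 cell line (Homo sapiens) as the target, read by sulforhodamine B assay; on this read-out lower numbers stand for stronger inhibition and higher numbers for weaker inhibition:
compound 1 `CCCc1ccc(NC2=CC(=O)c3nc4n(c3C2=O)[C@H]2OC[C@@H](O)[C@H]2OC4)cc1` gives > 4000 nM, a limit of the assay.
compound 2 `O=C1C(Nc2ccc(Br)cc2)=CC(=O)c2c1nc1n2[C@H]2OC[C@@H](O)[C@H]2OC1` gives 1980 nM.
compound 3 `Cc1ccc(NC2=CC(=O)c3c(nc4n3[C@H]3OC[C@@H](O)[C@H]3OC4)C2=O)cc1` gives > 4000 nM, a limit of the assay.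

Compound 1 stands at the limit, with compound 3; only compound 2 carries a number. Among the measured compounds shown here, the one measured step is an at least 2.0-fold higher number from compound 2 to compound 3 (0.30 log units; that floor lies within the scatter), running from a number to the limit (the limit of > 4000 nM in this assay, at which 2 of the 3 values shown sit). Compound 4 `O=C1C=C(Nc2cccc(Cl)c2)C(=O)c2c1nc1n2[C@H]2OC[C@@H](O)[C@H]2OC1` differs from compound 1 by 3-chlorophenyl in place of 4-propylphenyl on an amine nitrogen. For the measured compounds named here, no measured step covers this change directly; the nearest point of comparison is compound 2, whose bromo on the aromatic carbon gave a number where the propyl of compound 1 and the methyl of compound 3 gave only the limit. Compound 4 is therefore expected to sit near compound 2, a step of an at least 1.3-fold lower number from compound 1 to compound 4 (0.12 log units; that floor lies within the scatter) in this assay. The estimate for compound 4 is 3000 nM, within 1200 nM and 8000 nM.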

Compound 4, half-maximal inhibitory concentration: 4690 nM
Estimate against measurement, compound 4: 1.6-fold (0.19 log units) below; low and high end bracket the measured number.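

No step can be read from compound 1 to compound 4, because compound 1 stands at a limit and not at a number: the limit of > 4000 nM in this assay, at which 2 of the 4 values shown sit.

The compounds shown leave open how 3-chlorophenyl compares with 4-propylphenyl on an amine nitrogen.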